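Varied Aryl Ether Substituents Around Compound 2

The source may hold more compounds than are shown below. What is called first, only, known or untested is meant among the compounds shown, and "the series" means these compounds.

Compound 2 `Cc1nn(-c2ncnc3nc[nH]c23)c2c1C(OCCc1ccccc1)CC(=O)N2` gives 3 nM in a functional assay on HEK293 cells for agonist activity at G-protein coupled receptor 39 (Homo sapiens), read by scintillation proximity assay and inositol phosphate accumulation, with a stated time of 75 min, in the presence of a further agent that is not named here (on this read-out higher numbers stand for an effect only at larger amounts of compound and lower numbers for an effect already at smaller amounts), the lowest of the two measured numbers, while compound 1 `Cc1nn(-c2ncnc3nc[nH]c23)c2c1C(OCc1ccc(Cl)cc1Cl)CC(=O)N2` gives 4 nM in this assay, within the scatter of compound 2. Going by the values given here, the one measured step, a 1.3-fold lower number from compound 1 to compound 2 (0.12 log units; within the scatter), bears on compound 3 `Cc1nn(-c2ncnc3nc[nH]c23)c2c1C(OCc1cc(F)cc3c1OCOC3)CC(=O)N2`, which has not yet been measured. The change itself is a group of 11 heavy atoms (8 carbon, 2 oxygen, 1 fluorine; one six-membered non-aromatic ring with 2 hetero atoms, one six-membered aromatic ring of carbon only) in place of a group of 7 heavy atoms (7 carbon; one six-membered aromatic ring of carbon only), on a saturated chain carbon bound to an oxygen on a saturated carbon. Because a 1.3-fold lower number from compound 1 to compound 2 (0.12 log units; within the scatter) stayed within the scatter, compound 3 is expected to show a 1.3-fold higher number from compound 2 to compound 3 (0.12 log units; within the scatter), no shift beyond the scatter. Compound 3 is therefore estimated at 4 nM, with a range from 1.5 nM to 12 nM.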

Compound 3, half-maximal effective concentration: 1.5 nM
Compound 3: middle estimate off by 2.7-fold (0.43 log units), on the high side, and the stated range covers the measured number.
By their numbers in this assay, from the lowest: compounds 3, 2 and 1 (each within the scatter of the next, the first and the last beyond it).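

At this position, on a saturated chain carbon bound to an oxygen on a saturated carbon, the fused group with its six-membered non-aromatic ring and fluorine replaces benzyl with a 2.0-fold lower number from compound 2 to compound 3 (0.30 log units; within the scatter) staying within the scatter. Set against 2,4-dichlorophenyl, the same group gives the first step here beyond the scatter, a 2.7-fold lower number from compound 1 to compound 3 (0.43 log units; beyond the scatter) and modest in size. No evidence is at hand on what lies behind this step. Still open, on these data alone, is whether the fluorine or the non-aromatic ring carries the step, and how an amine, a carboxylic acid or a longer chain would fare here.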